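The source may hold more compounds than are shown below. What is called first, only, known or untested is meant among the compounds shown, and "the series" means these compounds.

Working notes on the series in a functional assay on A549 cells (Homo sapiens) for cytotoxicity, read by sulforhodamine B assay, with a stated time of 48 h; on this read-out lower numbers stand for stronger inhibition of growth and higher numbers for weaker inhibition of growth

Three compounds of this set have numbers in this assay. Compound 1 `Nc1nc(Cl)c2ncn(Cc3ccccc3CCl)c2n1` gives 21900 nM and stands at the highest of the three numbers. Compound 3 `Nc1nc(Cl)c2ncn(Cc3cccc(CCl)c3)c2n1` gives 12300 nM, which lies within the usual scatter of the number for compound 1, so the two cannot be ranked against each other. Compound 2 `ClCc1ccccc1Cn1cnc2nc(Cl)nc(Cl)c21` gives 2810 nM, a gap from compound 1 that lies beyond the scatter; compound 2 differs from compound 1 in more than one place, so the pair is not a single step and no cause is drawn from it.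

Among the compounds with values here, no pair of measured compounds differs in one place only, so no measured step is available.

Compound 4 `ClCc1ccccc1Cn1cnc2c(Cl)ncnc21` has not yet been measured in this assay. Relative to compound 1 the change is hydrogen in place of amino on an aromatic carbon. The shared core is otherwise kept, as is the chloromethylbenzyl group.

Given that compound 2, which also carries no amino group, sits at 2810 nM while compound 1 sits at 21900 nM, the expected step of a 2.4-fold lower number from compound 1 to compound 4 (0.39 log units; beyond the scatter) is a moderate move toward lower numbers, with a real chance it stays within the scatter. Compound 4 is estimated at 9000 nM, with a range from 2500 nM to 30000 nM.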

Compound 4, concentration for 50% growth inhibition: 7760 nM
Beside the measured number, compound 4's estimate is 1.2-fold (0.06 log units) above it; the range from low to high includes it.
By their numbers in this assay, from the lowest: compound 2; then compounds 4, 3 and 1 (each within the scatter of the next, the first and the last beyond it).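

In this assay, within the data shown here, hydrogen in place of amino on the aromatic carbon between two ring nitrogen atoms gives a 2.8-fold lower number from compound 1 to compound 4 (0.45 log units; beyond the scatter) and provides the first single-place step, a modest one that lies beyond the scatter. The amino group at this place is therefore not required for growth inhibition in this assay: with the shared core and the chloromethylbenzyl group held constant, its loss goes with stronger inhibition, not weaker. No available measurement bears on what lies behind this step.

The compounds shown leave open whether the step reflects the loss of the amino group in particular or would be matched by other small groups on the same carbon, such as a methyl, a methoxy or a dimethylamino group. They also leave open whether the same exchange would give a step of similar direction and size on compound 3, which carries the chloromethyl group at a different place on the benzyl ring.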